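The compounds below may be only part of what the source reports. "The series", "measured", "known", "first", "only" and "open" are said of these compounds alone.

Compound 1 `CC(C)OC(=O)N1CCC(n2ncc3cc(-c4ccc(S(C)(=O)=O)cc4)ncc32)CC1` is the reference point of this small set. In a functional assay on HEK293 cells for agonist activity at Glucose-dependent insulinotropic receptor (Homo sapiens), read by cAMP accumulation, with a stated time of 30 min (on this read-out lower numbers stand for an effect already at smaller amounts and higher numbers for an effect only at larger amounts of compound), compound 1 gives 42 nM, the second highest of the three numbers measured. Compound 2 `CC(C)(C)OC(=O)N1CCC(n2ncc3cc(-c4ccc(S(C)(=O)=O)cc4)ncc32)CC1` gives 20 nM in this assay, and the step is a 2.1-fold lower number from compound 1 to compound 2 (0.32 log units; beyond the scatter). Compound 3 `CC(C)OC(=O)N1CCC(n2ncc3cc(-c4ccc(S(C)(=O)=O)nc4)ncc32)CC1` gives 197 nM, a step of a 4.7-fold higher number from compound 1 to compound 3 (0.67 log units; beyond the scatter).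

Compound 4 `CC(C)OC(=O)N1CCC(n2ncc3cc(-c4ccc(S(C)(=O)=O)cc4F)ncc32)CC1` differs from compound 1 by fluoro in place of hydrogen on an aromatic carbon. Neither measured step matches this change: the step from compound 1 to compound 2 concerns the carbamate end of the molecule, and the step from compound 1 to compound 3 swaps the whole six-membered aromatic ring of carbon only for a pyridine rather than adding a single atom to it. Both steps were of modest size, the larger one being the exchange on that ring. The present change is smaller in what it adds, so he expects a step within the scatter, with no clear direction, for compound 4, namely a 1.1-fold lower number from compound 1 to compound 4 (0.02 log units; within the scatter). His estimate for compound 4 in this assay is 40 nM, expected to lie between 15 nM and 110 nM.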

Compound 4, half-maximal effective concentration: 27 nM
Compound 4: middle estimate off by 1.5-fold (0.17 log units), on the high side, and the stated range covers the measured number.
By their numbers in this assay, from the lowest: compounds 2, 4 and 1 (each within the scatter of the next, the first and the last beyond it); then compound 3.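

Fluoro in place of hydrogen on this aromatic carbon, ortho to a large group and meta to a methylsulfonyl group, gives in this assay a 1.6-fold lower number from compound 1 to compound 4 (0.19 log units; within the scatter), so this position takes the added fluorine without a step beyond the scatter. The exchange of the whole ring for 6-(methylsulfonyl)pyridin-3-yl gave a 4.7-fold higher number from compound 1 to compound 3 (0.67 log units; beyond the scatter), whereas this single change on the ring stays within the scatter. Nothing at hand explains the size of the step.

The compounds shown leave open how chloro, methoxy or a nitrile would read on this same carbon, and so whether the position stays as undemanding with larger groups. Also open, as far as these compounds go, is whether fluoro and the added methyl of compound 2 would read any differently together than each does alone.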